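Triazole substitution pattern and maximal response in the aminoimidazoline series

The compounds below may be only part of what the source reports. "The series", "measured", "known", "first", "only" and "open" are said of these compounds alone.

Of the compounds shown here, two have been read in a functional assay with Alpha-1D adrenergic receptor (Homo sapiens) as the target, read by calcium flux; a higher number here means a larger maximal response, a lower number a smaller maximal response. Compound 1 `CCn1ncnc1-c1ccccc1NCC1=NCCN1` gives 55% in this assay. Among the measured compounds shown here, compound 2 `Cc1n[nH]c(-c2ccccc2NCC2=NCCN2)n1` gives 0%, the lowest of the two numbers; its nearest neighbour, compound 1, lies above it by a margin beyond the usual scatter, and no single-point step between measured compounds connects them. The next compound, compound 3 `Cn1ncnc1-c1ccccc1NCC1=NCCN1`, is the rearranged isomer of compound 2: 1-methyl-1H-1,2,4-triazol-5-yl in place of 3-methyl-1H-1,2,4-triazol-5-yl on an aromatic carbon. Compound 3 resembles compound 1 more closely than compound 2 does. A sizeable upward step is expected from compound 2 to compound 3 in this assay, estimated as a number 40 percentage points higher from compound 2 to compound 3 (beyond the scatter), because compound 1 gives 55% while compound 2 gives 0%. For compound 3 the expected value in this assay is 40%, with a plausible range from 10% to 70%, given that only two points anchor the series.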

Compound 3, largest response reached (reported as maximal response), in percent of the reference or control that the assay uses: 116%
The estimate for compound 3 lay 76 percentage points below the measured number; measured number above the stated range.
By their numbers in this assay, from the lowest: compound 2; then compound 1; then compound 3.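

In this assay the swap of 3-methyl-1H-1,2,4-triazol-5-yl for 1-methyl-1H-1,2,4-triazol-5-yl gives a number 116 percentage points higher from compound 2 to compound 3 (beyond the scatter) with the atoms unchanged, so how the same atoms are joined in this group on the aromatic carbon can by itself decide the maximal response. The chain on the ring nitrogen also counts: hydrogen in place of methyl on the saturated chain carbon bound to that aromatic nitrogen gives a number 61 percentage points higher from compound 1 to compound 3 (beyond the scatter) as a second large step in this series. Nothing at hand accounts for either step.

Open, on these data alone, is whether a propyl or cyclopropyl group on that ring nitrogen would continue the trend in the opposite direction from methyl, or whether an unsubstituted triazole would keep the response. As far as these compounds go, it is also open whether the large step from the methyl swap would hold with a fluorine or methoxy group on the six-membered aromatic ring.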